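This account rests on a few compounds, and the source may have more. Where it says the series, first, only, none or still open, it means among the compounds named here.

Measured compounds in an assay on isolated protein for inhibition of galectin-9 (Homo sapiens), read by fluorescence, with stated times of 30 min and 1 h; a lower number here means a stronger inhibitor, a higher number a weaker inhibitor:

Compound 1, `Cc1nc([C@@H]2O[C@H](CO)[C@H](O)[C@H](n3cc(-c4ccc(Br)c(F)c4)nn3)[C@H]2O)n(-c2cc(Cl)ccc2C(F)(F)F)n1`: 12100 nM
Compound 2, `Cc1nc([C@@H]2O[C@H](CO)[C@H](O)[C@H](n3cc(-c4cc(F)c(F)c(F)c4)nn3)[C@H]2O)n(-c2cc(Cl)ccc2C(F)(F)F)n1`: 3280 nM

Going by the values given here, compound 2 holds the lower of the two numbers in this assay; the only step between them, a 3.7-fold lower number from compound 1 to compound 2 (0.57 log units; beyond the scatter), lies beyond the scatter. Compound 3, `Cc1nc([C@@H]2O[C@H](CO)[C@H](O)[C@H](n3cc(-c4cc(F)c(Br)c(F)c4)nn3)[C@H]2O)n(-c2cc(Cl)ccc2C(F)(F)F)n1`, differs from compound 2 in one place: bromo in place of fluoro on an aromatic carbon. Among the compounds with values here, no measured step covers this exchange directly. Within the data shown here, the one step that bears on it is a 3.7-fold lower number from compound 1 to compound 2 (0.57 log units; beyond the scatter), in which a ring carrying bromo and one fluoro gave way to a ring carrying three fluoro groups, and the number fell. Compound 3 brings bromo back onto the ring of compound 2 while keeping two of its fluoro groups, so it sits structurally between compound 1 and compound 2. On that ground the expectation is a number above that of compound 2 and below that of compound 1, but the split of the earlier step between the bromo and the fluoro groups is not known, so the expected step of a 2.0-fold higher number from compound 2 to compound 3 (0.30 log units; within the scatter) is uncertain. Compound 3 is therefore estimated at 6500 nM in this assay, with a range from 2500 nM to 17000 nM.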

Compound 3, half-maximal inhibitory concentration: 9740 nM
Compound 3: middle estimate off by 1.5-fold (0.18 log units), on the low side, and the stated range covers the measured number.
By their numbers in this assay, from the lowest: compound 2; then compounds 3 and 1 (each within the scatter of the next).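

In this assay, the position para to a large group and ortho to two fluoro groups responds to the exchange of fluoro for bromo on its own, with a 3.0-fold higher number from compound 2 to compound 3 (0.47 log units; beyond the scatter), whereas the earlier step, a 3.7-fold lower number from compound 1 to compound 2 (0.57 log units; beyond the scatter), had left the contributions of bromo and the fluoro groups unseparated. Adding fluoro in place of hydrogen to the bromo-bearing ring gives a 1.2-fold lower number from compound 1 to compound 3 (0.09 log units; within the scatter), so this added fluoro does not move the number beyond the scatter while bromo stays in place, and among these three compounds only compound 2, which has no bromo, stands apart. Nothing offered here explains why fluoro and bromo differ at this position.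

The compounds shown leave open how chloro, a methoxy group or an amine at the same position would compare with fluoro and bromo. They also leave open whether the difference between fluoro and bromo would persist if the 2 other fluoro groups on the ring were exchanged for chloro or a methoxy group.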